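The source may hold more compounds than are shown below. What is called first, only, known or untested is meant among the compounds shown, and "the series" means these compounds.

Compound 1 `COc1cccc(CNC(=O)c2nc(Br)c3cccnc3c2N[C@H]2CC[C@H](N)CC2)c1`: 7000 nM
Compound 2 `O=C(NCc1ccc(F)cc1)c1nc(Br)c2cccnc2c1N1CCNCC1`: 8000 nM

In a functional assay on MDA-MB-435 cells (Homo sapiens) for cytotoxicity, read by MTT assay, with a stated time of 72 h (a lower number here means a stronger inhibitor, a higher number a weaker inhibitor), compound 1 gives 7000 nM and compound 2 gives 8000 nM; the two numbers lie within the usual scatter of each other, so neither stands apart. Compound 3 `N[C@H]1CC[C@H](Nc2c(C(=O)NCc3ccccc3)nc(Br)c3cccnc23)CC1` has not yet been measured. It differs from compound 1 in one place: hydrogen in place of methoxy on an aromatic carbon. For the measured compounds named here, no measured pair here shows what this change does. The step is expected to be small, with no direction beyond the scatter: a 1.1-fold higher number from compound 1 to compound 3 (0.06 log units; within the scatter). Compound 3 is therefore estimated at 8000 nM, within a range from 3000 nM to 20000 nM.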

Compound 3, half-maximal inhibitory concentration: 7000 nM
The estimate for compound 3 lay 1.1-fold (0.06 log units) above the measured number; low and high end bracket the measured number.
By their numbers in this assay, from the lowest: compounds 1, 3 and 2 (each within the scatter of the next).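

In this assay, going from 3-methoxybenzyl to benzyl gives no change at the digits printed from compound 1 to compound 3 (within the scatter) in this first pair of compounds differing in one place. At this place on the ring, then, hydrogen can stand in for methoxy without the number moving beyond the scatter. No measurement here speaks to why the number holds.

Only methoxy and hydrogen are compared at this ring carbon, so one pair cannot show how much the position tolerates. As far as these compounds go, what an amine or a carboxylic acid would do there remains open.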